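This account rests on a few compounds, and the source may have more. Where it says the series, first, only, none or still open, it means among the compounds named here.

Of the compounds shown here, two have been measured in a functional assay on CHO cells for agonist activity at Free fatty acid receptor 1 (Homo sapiens), read by FLIPR and calcium flux; a lower number here means that less compound is needed, a higher number that more compound is needed for the effect. Compound 1, with the structure `COc1cc(C)c(-c2cccc(COc3ccc4c(c3)C(O)CC4CC(=O)O)c2)c(C)c1`, gives 550 nM in this assay. Compound 2, with the structure `O=C(O)CS(=O)(=O)c1ccc(OCc2cccc(-c3ccccc3Cl)c2)cc1`, gives 28.8 nM in this assay. Of these two numbers, compound 2 has the lower one, and the gap to compound 1 lies beyond the usual scatter, so compound 2 is the more potent of the pair.

Compound 3, with the structure `Cc1ccc(-c2cccc(COc3ccc(S(=O)(=O)CC(=O)O)cc3)c2)c(Cl)c1`, is not yet measured. It differs from compound 2 in one place: methyl in place of hydrogen on an aromatic carbon. Among the measured compounds shown here, no step of this kind has been measured here, so there is no measured pair to lean on. A single methyl added at this point is expected to give a step from compound 2 to compound 3 of a 1.2-fold lower number from compound 2 to compound 3 (0.06 log units; within the scatter), that is, nothing beyond the scatter. Compound 3 is therefore estimated at 25 nM in this assay, within a range from 8 nM to 80 nM.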

Compound 3, half-maximal effective concentration: 36.3 nM
Compound 3: middle estimate off by 1.5-fold (0.16 log units), on the low side, within the range that was stated.
By their numbers in this assay, from the lowest: compounds 2 and 3 (each within the scatter of the next); then compound 1.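

In this assay the change from 2-chlorophenyl to 2-chloro-4-methylphenyl gives a 1.3-fold higher number from compound 2 to compound 3 (0.10 log units; within the scatter) and so leaves the two compounds indistinguishable. Among the compounds shown here, this is the first measured step, and it shows that this ring position, para to a large group and meta to the chloro group, accepts one methyl with no difference that can be read beyond the scatter. Nothing measured here bears on what lies behind this result.

On these data alone, one small group says little about the limits of this position, so it remains open whether an amine or a longer carbon chain placed there would also stay within the scatter. As far as these compounds go, it also remains open whether a methyl would give a similar step at other positions on this ring or in a compound lacking the chloro group.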